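This account rests on a few compounds, and the source may have more. Where it says the series, first, only, none or still open, it means among the compounds named here.

Compound 1 `CCN(Cc1ccccc1)Cc1nn(-c2ccccc2F)c2c1CCS(=O)(=O)O2` was measured in a physicochemical assay for lipophilicity, using the shake flask method, in phosphate buffer, measured as octanol-water partition, with a stated time of 48 h, at pH 7.4 (on this read-out lower numbers stand for lower lipophilicity and higher numbers for higher lipophilicity), and gave 2. Going by the values given here, the only other measured compound, compound 2 `O=S1(=O)CCc2c(C3CC3)nn(-c3ccccc3F)c2O1`, gave 2.09 in this assay; these two numbers lie within the usual scatter of each other, so nothing separates them. Compound 3 `CN(Cc1ccccc1)Cc1nn(-c2ccccc2F)c2c1CCS(=O)(=O)O2` has not yet been measured. It differs from compound 1 by hydrogen in place of methyl on a saturated chain carbon bound to an amine nitrogen. Among the compounds with values here, no measured pair shows this change, so the size of the step rests on expectation alone: a small downward step, a number 0.40 log units lower from compound 1 to compound 3 (beyond the scatter), reaching just past the scatter. Compound 3 is therefore expected to give 1.6, within a range from 1.2 to 2.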

Compound 3, partition coefficient: 1.78
Estimate against measurement, compound 3: 0.18 log units below; the measured number falls inside the stated range.
By their numbers in this assay, from the lowest: compounds 3, 1 and 2 (each within the scatter of the next, the first and the last beyond it).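

In this assay, going by these compounds alone, the first measured pair at this place shows hydrogen in place of methyl on a saturated chain carbon bound to an amine nitrogen giving a number 0.22 log units lower from compound 1 to compound 3 (within the scatter). Shortening ethyl to methyl here therefore leaves the two compounds indistinguishable on this read-out. Nothing measured on these compounds offers an explanation for the size of this step.

On these data alone, a longer chain such as propyl, or a carboxylic acid, at this place remains open. So does whether removing the benzyl group from the amine nitrogen would give a step beyond the scatter.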